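Replacing benzamido with isopropoxy at the assay limit

This account rests on a few compounds, and the source may have more. Where it says the series, first, only, none or still open, it means among the compounds named here.

Compound 1 (`COc1ccc(C2=C(c3cc(OC)c(OC)c(OC)c3)C(=O)C(O)C2)cc1NC(=O)c1ccccc1`) gives > 100 ug/mL in an ADME assay on DU-145 cells (Homo sapiens) for cytotoxicity, read by MTT assay, with a stated time of 72 h (on this read-out lower numbers stand for stronger inhibition and higher numbers for weaker inhibition), and this is a limit of the assay, not a number. Compound 2 (`COc1cc(C2=C(c3ccc(OCC(=O)O)cc3)C(O)CC2=O)cc(OC)c1OC`) gives > 100 ug/mL as a limit in this assay as well. Compound 3 (`COc1ccc(C2=C(c3cc(OC)c(OC)c(OC)c3)C(=O)CC2OC(C)=O)cc1NC=O`) likewise returns > 100 ug/mL as a limit in this assay and no number. Compound 1 therefore stands level with the only other data available, and the whole picture is the limit of > 100 ug/mL in this assay, at which 3 of the 3 values shown sit, and nothing finer. Within the data shown here, no measured step between compounds is available to guide a prediction.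

Compound 4 (`COc1ccc(C2=C(c3cc(OC)c(OC)c(OC)c3)C(=O)C(O)C2)cc1OC(C)C`) is still to be measured in this assay and differs from compound 1 in one place. The count reads isopropoxy in place of benzamido on an aromatic carbon with isopropoxy in place of benzamido on an aromatic carbon, ortho to a methoxy group. A move toward stronger inhibition is expected, but its size is uncertain. The estimated step is an at least 2.5-fold lower number from compound 1 to compound 4 (0.39 log units; beyond the scatter) and runs toward lower numbers, though another report of only a limit remains quite possible. The estimated value for compound 4 is 40 ug/mL in this assay with an expected range of 5 ug/mL to 150 ug/mL on that read-out.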

Compound 4, half-maximal inhibitory concentration: > 100 ug/mL
Compound 4 was reported as a limit (the forecaster's own chance of this, stated with the estimate: 45%); middle value at least 2.5-fold (0.39 log units) away from the limit.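

Compound 1 and compound 4 each return only a limit, so the swap of benzamido for isopropoxy gives no readable step in this assay because neither compound has a number to compare: the limit of > 100 ug/mL in this assay, at which 4 of the 4 values shown sit.

The compounds shown leave open how far apart these two compounds truly lie and whether any change to the shared core would give a measurable value.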